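The compounds below may be only part of what the source reports. "The series", "measured", "known", "first", "only" and "open" are said of these compounds alone.

Three compounds have been measured in a functional assay on PC-3 cells (Homo sapiens) for cytotoxicity, read by MTT assay, with a stated time of 48 h; a higher number here means a weaker inhibitor, a lower number a stronger inhibitor:

Compound 1 `CC1=NN(C(=O)c2ccc(C)cc2)C(c2ccccc2O)C1` gives 40600 nM.
Compound 2 `CC1=NN(C(=O)COc2ccc(Cl)cc2)C(c2ccccc2O)C1` gives 38800 nM.
Compound 3 `CC1=NN(C(=O)COc2ccc(Cl)cc2)C(c2cc(Br)ccc2O)C1` gives 49000 nM.

Compound 2 carries the lowest of the three numbers, yet its gaps to compound 1 and to compound 3 are both within the scatter, so the three compounds cannot be placed in any order in this assay. For the measured compounds named here, the only step between compounds differing in a single place is a 1.3-fold higher number from compound 2 to compound 3 (0.10 log units; within the scatter), and it concerns the ring bearing the hydroxyl, not the chain on the carbonyl.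

Compound 4 `CCN(CC)CC(=O)N1N=C(C)CC1c1ccccc1O` differs from compound 2 by diethylamino in place of 4-chlorophenoxy on a saturated chain carbon bound to a carbonyl carbon. Going by the values given here, no measured step touches this part of the molecule, so the expectation rests only on the observation that none of the three measured compounds moves beyond the scatter from the others. Compound 4 is therefore expected to show no step beyond the scatter, which is what a 1.0-fold higher number from compound 2 to compound 4 (0.01 log units; within the scatter) expresses. The estimate for compound 4 in this assay is 40000 nM, with a range from 15000 nM to 110000 nM.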

Compound 4, half-maximal inhibitory concentration: 25900 nM
Compound 4: middle estimate off by 1.5-fold (0.19 log units), on the high side; measured number inside the range.
By their numbers in this assay, from the lowest: compounds 4, 2, 1 and 3 (each within the scatter of the next).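

The chain on the carbonyl now has measured steps in this assay: diethylamino in place of 4-chlorophenoxy gives a 1.5-fold lower number from compound 2 to compound 4 (0.18 log units; within the scatter), and (diethylamino)methyl in place of 4-methylphenyl gives a 1.6-fold lower number from compound 1 to compound 4 (0.20 log units; within the scatter). For the compounds shown here, until now, the only single-place step had concerned the ring bearing the hydroxyl, whereas these show that the six-membered aromatic ring of carbon only can leave this part of the molecule, with 8 heavy atoms giving way to 5, without any step beyond the scatter. Nothing available here explains these numbers.

From the compounds shown here alone, whether a morpholine, a carboxylic acid or a longer chain in place of diethylamino would produce a step beyond the scatter remains open. So does whether diethylamino would give a similar number alongside the bromo of compound 3.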